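This account rests on a few compounds, and the source may have more. Where it says the series, first, only, none or still open, it means among the compounds named here.

Of the compounds shown here, two built on one shared core have been measured in a functional assay on HCC1806 cells (Homo sapiens) for inhibition, read by sulforhodamine B assay, tested at 10 uM; on this read-out lower numbers stand for less inhibition and higher numbers for more inhibition at the one concentration tested (going by the name of the read-out). Compound 1 `CC(=O)N1N=C(c2ccc(-n3ccnc3)cc2)CC1c1ccc(N(C)C)cc1` gives -9.7% in this assay. Compound 2 `Cc1ccc(S(=O)(=O)N2N=C(c3ccc(-n4ccnc4)cc3)CC2c2ccc(N(C)C)cc2)cc1` gives 66% in this assay, the higher of the two numbers, and the step of a number 75.7 percentage points higher from compound 1 to compound 2 (beyond the scatter) separates them. Compound 3 `CN(C)c1ccc(C2CC(c3ccc(-n4ccnc4)cc3)=NN2S(=O)(=O)c2ccc([N+](=O)[O-])cc2)cc1` carries (4-nitrophenyl)sulfonyl where compound 2 carries (4-methylphenyl)sulfonyl, and the difference computed from the two structures is nitro in place of methyl on an aromatic carbon. Going by the values given here, the only measured step exchanges the group on an amine nitrogen in a ring and leaves the aromatic carbon changed here untouched, so it gives no direct guide to the size or direction of the present step. With compound 2 as the sole anchor, compound 3 is expected to stay close to it, and a change of a number 6 percentage points lower from compound 2 to compound 3 (within the scatter) is regarded as the likely outcome. Compound 3 is therefore estimated at 60%, within a range from 30% to 85%.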

Compound 3, a percentage reported as inhibition, at one concentration (the size of the read-out at that concentration, not a potency): 46.6%
Compound 3: the middle estimate sits 13.4 percentage points above what was measured; the range from low to high includes it.
By their numbers in this assay, from the lowest: compound 1; then compound 3; then compound 2.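

Compound 3 shows that the group on the aromatic carbon of the sulfonyl part also matters in this assay: the change from methyl to nitro gives a number 19.4 percentage points lower from compound 2 to compound 3 (beyond the scatter) and so counts as a modest but real step. The advantage of the sulfonyl group over acetyl on the ring nitrogen holds with the nitro group as well, with a number 56.3 percentage points higher from compound 1 to compound 3 (beyond the scatter) as the large step, so this exchange outweighs the change at the aromatic carbon in these compounds. No measured evidence bears on why nitro reads lower than methyl here.

As far as these compounds go, two groups at this aromatic carbon cannot define a trend, so it remains open where an amine, a methoxy group or a chlorine atom would fall. From the compounds shown here alone, it is also open whether a hydrogen there would read closer to methyl or to nitro.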